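The compounds below may be only part of what the source reports. "The series", "measured", "known", "first", "only" and "open" are said of these compounds alone.

Of the compounds shown here, two built on one shared core have so far been measured in a functional assay on the whole organism for inhibition, with Rattus norvegicus as the target; a lower number here means that less compound is needed, a higher number that more compound is needed for the effect. Compound 1, `CC1CCC(=NNc2ccccc2)c2ncc(C(=O)O)c(=O)n21`, carries a bare phenyl, and in this assay compound 1 gives 0.6 umol/kg. Compound 2, `CC1CC/C(=N\Nc2ccc(F)cc2)c2ncc(C(=O)O)c(=O)n21`, carries fluoro on an aromatic carbon of that phenyl, and in this assay compound 2 gives 12.2 umol/kg. For the measured compounds named here, compound 2 therefore stands at the highest of the two numbers, with compound 1 at the lower one; no step between the two has been worked out, and their two values alone tell the story.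

The next compound, compound 3, `COc1ccc(N/N=C2\CCC(C)n3c2ncc(C(=O)O)c3=O)cc1`, differs from compound 2 in a single place: methoxy in place of fluoro on an aromatic carbon. The change sits on an aromatic carbon of a six-membered aromatic ring of carbon only, para to a large group. Going by the values given here, no measured pair here shows what exchanging fluoro for methoxy does, so the expectation rests on the position alone, where compound 2 already sits high. In this assay the expected step is a 1.2-fold higher number from compound 2 to compound 3 (0.09 log units; within the scatter), a shift that stays within the scatter. Compound 3 is thus expected to give about 15 umol/kg in this assay, with a likely range from 5 umol/kg to 50 umol/kg.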

Compound 3, dose for 50% inhibition: 0.8 umol/kg
Beside the measured number, compound 3's estimate is 19-fold (1.27 log units) above it; the whole stated range lies above it.
By their numbers in this assay, from the lowest: compounds 1 and 3 (each within the scatter of the next); then compound 2.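

The step of a 15-fold lower number from compound 2 to compound 3 (1.18 log units; beyond the scatter) in this assay, made by putting methoxy in place of fluoro, shows that the group on this aromatic carbon, para to a large group, can shift the dose needed by a wide margin. It also changes how compound 2 reads: a group at this place does not by itself go with a high number, since compound 1, with its bare phenyl, gives 0.6 umol/kg and compound 3, with its methoxy, gives 0.8 umol/kg, two values within the usual scatter of each other. Among these three compounds, only the fluoro of compound 2 goes with the higher number, and no measurement at hand explains why fluoro and methoxy part so sharply here.

For the compounds shown here, with only two groups on this carbon, it remains open whether others, such as chloro, methyl or an amine, would fall with fluoro or with methoxy and the bare phenyl. As far as these compounds go, it is equally open whether methoxy would give a similar number on another carbon of the same ring, or whether this result holds only for the place tested here.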